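The source may hold more compounds than are shown below. What is called first, only, known or untested is meant among the compounds shown, and "the series" means these compounds.

Among the measured compounds shown here, in an ADME assay on L02 cells (Homo sapiens) for inhibition, read by MTT assay, with a stated time of 72 h (on this read-out lower numbers stand for stronger inhibition and higher numbers for weaker inhibition), compound 3 `C/C=C/C(=O)Nc1cccc(Oc2nc(Nc3cccc(C#N)c3)nc3ccsc23)c1` gives 47900 nM, one of only two plain numbers in this set, and a value that lies within the scatter of compound 1 `C/C=C/C(=O)Nc1cccc(Oc2nc(Nc3cccc(OC)c3)nc3ccsc23)c1`, which gives 46000 nM. Compound 2 `CC/C=C/C(=O)Nc1cccc(Oc2nc(Nc3cccc(OC)c3)nc3ccsc23)c1` is reported in this assay only as a limit, > 50000 nM. Beyond that, the one remaining comparison among the measured compounds is a 1.0-fold higher number from compound 1 to compound 3 (0.02 log units; within the scatter).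

Compound 4 `CC/C=C/C(=O)Nc1cccc(Oc2nc(Nc3cccc(C#N)c3)nc3ccsc23)c1` differs from compound 3 by methyl in place of hydrogen on a saturated chain carbon bound to a double-bonded chain carbon. Exactly this change has been measured once in this assay, as an at least 1.0-fold higher number from compound 1 to compound 2 (0.03 log units; that floor lies within the scatter), a step that ends at the limit of > 50000 nM in this assay, at which 1 of the 3 values shown sits. That precedent points to no shift beyond the scatter for compound 4, together with a real chance that the measurement again stops at the limit rather than giving a number. The step expected from compound 3 to compound 4 is therefore a 1.1-fold higher number from compound 3 to compound 4 (0.06 log units; within the scatter). Compound 4 is estimated at 55000 nM, with a range from 30000 nM to 100000 nM.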

Compound 4, half-maximal inhibitory concentration: > 50000 nM
Compound 4 gave a limit, no number (the forecaster's own chance of this, stated with the estimate: 60%); the middle value does not contradict the limit.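

In this assay, compound 4 gives > 50000 nM, which is a limit and not a number. The change from prop-1-en-1-yl to but-1-en-1-yl, tried before only with the methoxy group present, now also stands with the nitrile in its place, and it reads as an at least 1.0-fold higher number from compound 3 to compound 4 (0.01 log units; that floor lies within the scatter), so neither case shows a shift beyond the scatter: the same change on two cores in this assay, an at least 1.0-fold higher number (0.03 log units; that floor lies within the scatter) from compound 1 to compound 2 and an at least 1.0-fold higher number (0.01 log units; that floor lies within the scatter) from compound 3 to compound 4; the limit leaves it open whether they differ. The limit now shapes this small set as much as the plain numbers do: the limit of > 50000 nM in this assay, at which 2 of the 4 values shown sit.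

On these data alone, the step from compound 2 to compound 4 cannot be read, and the true values of both compounds stay unknown. As far as these compounds go, it also remains open whether an amine in place of the added methyl would give a plain number in this assay.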